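A few compounds are considered here, and "the series" means these few. Any claim that something is new, unique, unknown or untested is made for them only; others in the source may bear on it.

Measured in a functional assay on PC-6 cells (Homo sapiens) for cytotoxicity, read by MTT assay, with a stated time of 3 days; on this read-out lower numbers stand for stronger inhibition and higher numbers for weaker inhibition:
- compound 1 `CN(C)Cc1ccc(/C=N/Nc2ncnc3sc(C(C)(C)C)cc23)cc1`: 0.107 ug/mL
- compound 2 `CC(C)(C)c1cc2c(N/N=C/c3ccc(CN)cc3)ncnc2s1`: 0.214 ug/mL
- compound 3 `CC(C)(C)c1cc2c(N/N=C/c3ccc(CO)cc3)ncnc2s1`: 0.556 ug/mL

Compound 3 stands highest of the three, so it is the weakest inhibitor so far. The change to compound 4 `CNCc1ccc(/C=N/Nc2ncnc3sc(C(C)(C)C)cc23)cc1` is methylamino in place of hydroxy on a saturated chain carbon bound to an aromatic carbon. Going by the values given here, two measured steps bear on it, read in reverse: a 2.6-fold higher number from compound 2 to compound 3 (0.41 log units; beyond the scatter) and a 5.2-fold higher number from compound 1 to compound 3 (0.72 log units; beyond the scatter). Replacing dimethylamino with amino gives a 2.0-fold higher number from compound 1 to compound 2 (0.30 log units; within the scatter). On these steps, a modest drop in the number is expected in this assay, with compound 4 close to compound 1 and compound 2. The expected step is a 3.7-fold lower number from compound 3 to compound 4 (0.57 log units; beyond the scatter). For compound 4 the estimated value is 0.15 ug/mL, with an expected range of 0.08 ug/mL to 0.3 ug/mL.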

Compound 4, half-maximal inhibitory concentration: 0.044 ug/mL
The estimate for compound 4 lay 3.4-fold (0.53 log units) above the measured number; the measured number lies below the stated range.
By their numbers in this assay, from the lowest: compound 4; then compounds 1 and 2 (each within the scatter of the next); then compound 3.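

In this assay, methylamino is the best of the three amines at this saturated chain carbon, so the number does not move in one direction as methyls are added to the amine nitrogen: adding one gives a 4.9-fold lower number from compound 2 to compound 4 (0.69 log units; beyond the scatter), while removing one gives a 2.4-fold lower number from compound 1 to compound 4 (0.39 log units; beyond the scatter). The step from the hydroxy compound, a 13-fold lower number from compound 3 to compound 4 (1.10 log units; beyond the scatter), is the largest seen at this position and is large, whereas the earlier amine-to-hydroxy steps were modest. Nothing available accounts for this turn.

As far as these compounds go, whether ethylamino or a cyclic amine such as pyrrolidine keeps or loses this gain remains open. So does the effect of a longer chain between the aromatic carbon and the methylamino nitrogen.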